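The compounds below may be only part of what the source reports. "The series", "measured", "known", "first", "only" and "open" are said of these compounds alone.

Measured in a functional assay on U-87MG ATCC cells for antiproliferative activity against U-87 MG (Homo sapiens), read by spectrophotometry, with a stated time of 2 days; on this read-out higher numbers stand for weaker inhibition of growth and lower numbers for stronger inhibition of growth:
compound 1 `COc1ccc(Nc2ncc(C(F)(F)F)c(N3Cc4cccc(N(C)S(C)(=O)=O)c4C3)n2)cc1C(F)(F)F`: 29400 nM
compound 2 `CN(c1cccc2c1CN(c1nc(Nc3cc(C(F)(F)F)cc(C(F)(F)F)c3)ncc1C(F)(F)F)C2)S(C)(=O)=O`: 16800 nM
compound 3 `Cc1ccc(Nc2ncc(C(F)(F)F)c(N3Cc4cccc(N(C)S(C)(=O)=O)c4C3)n2)c(C)c1`: > 30000 nM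

Compound 3 stands at the limit of > 30000 nM in this assay, at which 1 of the 3 values shown sits, so it offers a limit and no number.

Compound 4 `CN(c1cccc2c1CN(c1nc(Nc3cccc(C(F)(F)F)c3)ncc1C(F)(F)F)C2)S(C)(=O)=O` differs from it as follows: 3-(trifluoromethyl)phenyl in place of 2,4-dimethylphenyl on a nitrogen on an aromatic ring.

Going by the values given here, the only measured step on this group is an at least 1.0-fold higher number from compound 1 to compound 3 (0.00 log units; that floor lies within the scatter), and it gives a floor and no size. Compound 1 also carries trifluoromethyl on this ring and gives 29400 nM, while compound 2 carries it too and gives 16800 nM. On those two values, a small fall in the number is expected, close to the scatter: an at least 1.3-fold lower number from compound 3 to compound 4 (0.13 log units; that floor lies within the scatter). A reading at the limit remains possible. The value expected for compound 4 is 22000 nM, within an estimated range of 11000 nM to 32000 nM.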

Compound 4, concentration for 50% growth inhibition: > 30000 nM
Compound 4: only a limit was reported (the forecaster's own chance of this, stated with the estimate: 35%); middle value at least 1.3-fold (0.13 log units) away from the limit.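

In this assay compound 4 gives > 30000 nM, a limit and not a number. Hydrogen in place of trifluoromethyl gives an at least 1.7-fold higher number from compound 2 to compound 4 (0.25 log units; that floor lies within the scatter), and hydrogen in place of methoxy gives an at least 1.0-fold higher number from compound 1 to compound 4 (0.00 log units; that floor lies within the scatter), so neither removal is shown to change growth inhibition. The step between compound 3 and compound 4 cannot be read, and compound 4 now sits at the limit as well: the limit of > 30000 nM in this assay, at which 2 of the 4 values shown sit.

Going by these compounds, the true distance between compound 3 and compound 4 stays open. So does whether an amine or a carboxylic acid on this phenyl ring would give a lower number than compound 2.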